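The source may report more compounds than this note shows. Statements on the series, on what has been measured and on what is new or still open speak of the compounds shown alone.

Working notes on the series. Compound 1 `Fc1ccccc1-c1ccc2[nH]c(/C=C/C3CCCCC3)nc2c1` gives 21 nM in a functional assay on HEK293 cells for antagonist activity at transient receptor potential M8 protein (Canis lupus familiaris), read by FLIPR and calcium flux; a lower number here means a stronger inhibitor, a higher number a weaker inhibitor. Compound 2 `FC(F)(F)Oc1ccccc1-c1ccc2[nH]c(/C=C/C3CCCCC3)nc2c1` carries trifluoromethoxy in place of fluoro on an aromatic carbon and in this assay compound 2 gives 14 nM. Going by the values given here, the step of a 1.5-fold lower number from compound 1 to compound 2 (0.18 log units; within the scatter) is the only measured step so far, and it lies within the scatter, so the two values of compound 1 and compound 2 stand together; compound 2 is one of two numbers, its nearest neighbour being compound 1 within the scatter.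

Compound 3 `FC(F)(F)Oc1ccccc1-c1ccc2[nH]c(/C=C/C3CCCC3)nc2c1` has not been measured. Its difference from compound 2 is cyclopentyl in place of cyclohexyl on a double-bonded chain carbon bound to a double-bonded chain carbon. Among the compounds with values here, no measured step bears on this part of the molecule: the one step known, a 1.5-fold lower number from compound 1 to compound 2 (0.18 log units; within the scatter), concerns the substituent on the aromatic carbon and not the ring on the double-bonded chain carbon. There is therefore no basis in the measured pairs for expecting a step beyond the scatter in either direction, and the expectation is a value close to that of compound 2 with a wide range. Compound 3 is expected to give 22 nM in this assay, between 7 nM and 70 nM. This corresponds to an expected step of a 1.6-fold higher number from compound 2 to compound 3 (0.20 log units; within the scatter).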

Compound 3, half-maximal inhibitory concentration: 110 nM
Compound 3: the middle estimate sits 5.0-fold (0.70 log units) below what was measured; measured number above the stated range.
By their numbers in this assay, from the lowest: compounds 2 and 1 (each within the scatter of the next); then compound 3.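

In this assay, the ring on the double-bonded chain carbon proves to be a sensitive part of the series: cyclopentyl in place of cyclohexyl gives a 7.9-fold higher number from compound 2 to compound 3 (0.90 log units; beyond the scatter), whereas the earlier pair, which differed only in the substituent on an aromatic carbon, showed no step beyond the scatter. Neither group carries a hydrogen-bond donor, a hydrogen-bond acceptor or a net charge, so the two compounds differ at this place only in the size of an all-carbon non-aromatic ring, and that single change is enough for a step of this size. Nothing measured on these compounds speaks to why the smaller ring goes with the higher number.

On these data alone, it remains open whether the trend extends in the other direction, with a cycloheptyl ring, or how the number responds to a phenyl ring or an open longer alkyl chain on the same chain carbon. Also open, as far as these compounds go, is whether the same change from cyclohexyl to cyclopentyl would give a step of similar size on compound 1, which has fluoro in place of trifluoromethoxy.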